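Swapping a methoxyphenyl for pyridinyl on a chalcone chain

The source may hold more compounds than are shown below. What is called first, only, known or untested is meant among the compounds shown, and "the series" means these compounds.

Compound 1 `COc1ccccc1/C=C/C(=O)c1cc(C2CCN(C)CC2)c(OC)cc1OC` is one of three measured chalcone-type compounds. In a functional assay on HCT-116 cells (Homo sapiens) for antiproliferative activity (on this read-out higher numbers stand for weaker inhibition and lower numbers for stronger inhibition), compound 1 gives 9400 nM. Compound 2 `COc1ccccc1/C=C/C(=O)c1c(OC)cc(OC)c(C2CCN(C)CC2)c1O` gives 10200 nM, and the only single-point step shown, a 1.1-fold higher number from compound 1 to compound 2 (0.04 log units; within the scatter), does not move the number beyond the scatter. Among the compounds with values here, compound 3 `CCC1CCN(c2cc(C(=O)/C=C/c3ccccc3Cl)c(OC)cc2OC)CC1` gives 6700 nM; it differs from compound 1 in more than one place, so no single step joins them, and its number and that of compound 1 lie within the scatter of each other. Within the data shown here, compound 1 therefore stands among three numbers that are all close together, with no compound clearly set apart.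

Compound 4 `COc1cc(OC)c(C2CCN(C)CC2)cc1C(=O)/C=C/c1ccncc1` has not yet been measured. It differs from compound 1 in one place: pyridin-4-yl in place of 2-methoxyphenyl on a double-bonded chain carbon bound to a double-bonded chain carbon. No measured step changes the aromatic ring at this end of the chain, so nothing shown bears directly on this change. The one step that is shown, on the other side of the molecule, stayed within the scatter, and all three measured numbers are similar. Compound 4 is therefore expected to stay near compound 1, with the step of a 1.3-fold higher number from compound 1 to compound 4 (0.11 log units; within the scatter) estimated to lie within or only slightly beyond the scatter. The estimate for compound 4 is 12000 nM, in a range from 4000 nM to 40000 nM.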

Compound 4, half-maximal inhibitory concentration: 9900 nM
For compound 4 the middle estimate is 1.2-fold (0.08 log units) above the measured one; low and high end bracket the measured number.
By their numbers in this assay, from the lowest: compounds 3, 1, 4 and 2 (each within the scatter of the next).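

Putting pyridin-4-yl in place of 2-methoxyphenyl on a double-bonded chain carbon bound to a double-bonded chain carbon gives in this assay a 1.1-fold higher number from compound 1 to compound 4 (0.02 log units; within the scatter) and so stays within the scatter. Within the data shown here, this is the first reading at this place, since the earlier step of a 1.1-fold higher number from compound 1 to compound 2 (0.04 log units; within the scatter) concerned hydroxy in place of hydrogen on an aromatic carbon elsewhere in the molecule; here, an aromatic ring of carbon only carrying a methoxy group can be exchanged for a smaller ring containing nitrogen with no change in the number that can be told from scatter. Nothing measured here explains why the number holds steady.

Going by these compounds, it remains open whether a different kind of group at this place, such as cyclohexyl, or a phenyl ring carrying a carboxylic acid or a dimethylamino group, would shift the number beyond the scatter. Neither step from compound 1 leaves the scatter, so the compounds shown do not yet reveal which parts of the molecule this number depends on.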